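The source may hold more compounds than are shown below. What is called first, only, known or untested is meant among the compounds shown, and "the series" means these compounds.

Compound 1 `COc1cc(-n2cnc3ccc(-c4ccccc4Cl)cc32)cc(OC)c1OC` gives > 10000 nM in a functional assay on MCF7 cells (Homo sapiens) for antiproliferative activity, read by MTT assay, with a stated time of 72 h (a higher number here means a weaker inhibitor, a lower number a stronger inhibitor), which is a limit of the assay rather than a number.
Compound 2 `COc1cc(-n2cnc3ccc(-c4cccc(F)c4)cc32)cc(OC)c1OC` gives 2350 nM.
Compound 3 `COc1cc(-n2cnc3ccc(-c4cccc(N)c4)cc32)cc(OC)c1OC` gives 180 nM.

Compound 1 thus stands only at the limit (the limit of > 10000 nM in this assay, at which 1 of the 3 values shown sits), with no number of its own. The step to compound 4 `COc1ccc(-c2ccc3ncn(-c4cc(OC)c(OC)c(OC)c4)c3c2)cc1` is 4-methoxyphenyl in place of 2-chlorophenyl on an aromatic carbon. For the measured compounds named here, no measured step makes this exact change, but two steps alter the same phenyl: an at least 4.2-fold lower number from compound 1 to compound 2 (0.62 log units; beyond the scatter) and an at least 55-fold lower number from compound 1 to compound 3 (1.74 log units; beyond the scatter); between those two, a 13-fold lower number from compound 2 to compound 3 (1.12 log units; beyond the scatter). Both departures from the 2-chlorophenyl gave a lower number, so a lower number is expected for compound 4 as well, of a size somewhere between these two steps. Compound 4 is therefore expected to give 500 nM, with a range of 80 nM to 3000 nM. This estimate is expected to amount to an at least 20-fold lower number from compound 1 to compound 4 (1.30 log units; beyond the scatter).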

Compound 4, half-maximal inhibitory concentration: 210 nM
Beside the measured number, compound 4's estimate is 2.4-fold (0.38 log units) above it; the measured number falls inside the stated range.
By their numbers in this assay, from the lowest: compounds 3 and 4 (each within the scatter of the next); then compound 2. At a limit, above all of these: compound 1.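

In this assay, the 4-methoxyphenyl group at this position gives an 11-fold lower number from compound 2 to compound 4 (1.05 log units; beyond the scatter) and an at least 47-fold lower number from compound 1 to compound 4 (1.67 log units; beyond the scatter). The comparison with the amino compound gives a 1.2-fold higher number from compound 3 to compound 4 (0.07 log units; within the scatter), so 3-aminophenyl is no longer the only group shown at this low level, although the two substituents differ in both identity and place on the phenyl.

Going by these compounds, whether 3-methoxyphenyl or 4-aminophenyl would give similar numbers remains open, and these would separate the substituent from its place. Compound 1 still has no number of its own, only a limit: the limit of > 10000 nM in this assay, at which 1 of the 4 values shown sits.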